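Ether substituent variation on a shared aminoquinoline-type core

This account rests on a few compounds, and the source may have more. Where it says the series, first, only, none or still open, it means among the compounds named here.

Measured compounds:
- compound 1, `CCC(C)COc1cccc2ccc(N)nc12`: 36 nM
- compound 2, `Nc1ccc2cccc(OCC3CC4CCC3C4)c2n1`: 137 nM
- compound 3, `Nc1ccc2cccc(OC3CCCCCC3)c2n1`: 137 nM

All three were run in an assay on cells with melanin-concentrating hormone receptor 1 (Homo sapiens) as the target, read by radioligand binding; on this read-out lower numbers stand for stronger inhibition and higher numbers for weaker inhibition. Compound 1, with the 2-methylbutyl ether, gives the lowest number of the three. Compound 2 and compound 3 both give higher numbers than compound 1, and in each case the gap to compound 1 lies beyond the scatter; the numbers for compound 2 and compound 3 are the same as each other, so nothing separates them.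

The next compound, compound 4, `Nc1ccc2cccc(OCC3CC3)c2n1`, is not yet measured. Relative to compound 1 the change is cyclopropyl in place of sec-butyl on a saturated chain carbon bound to an oxygen on an aromatic ring; cut one bond further out, the 2-methylbutyl ether becomes a cyclopropylmethyl ether. For the measured compounds named here, no measured pair in the set isolates this change, so the expectation rests on compound 1 alone and on the higher numbers seen for compound 2 and compound 3 with their other ring-bearing ethers.

The step expected is a 3.3-fold higher number from compound 1 to compound 4 (0.52 log units; beyond the scatter), toward a weaker value, and beyond the scatter. Compound 4 is estimated at 120 nM, with a range from 40 nM to 400 nM.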

Compound 4, half-maximal inhibitory concentration: > 2000 nM
Compound 4 was reported as a limit; the forecaster's own chance of this, stated with the estimate: 5%; at least 16-fold (1.22 log units) between middle value and limit.
By their numbers in this assay, from the lowest: compound 1; then compounds 2 and 3 (each within the scatter of the next). At a limit, above all of these: compound 4.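

In this assay compound 4 is reported only as a limit, > 2000 nM, so the true size of its step stays unread: the limit of > 2000 nM in this assay, at which 1 of the 4 values shown sits.

For the compounds shown here, on a saturated chain carbon bound to an oxygen on an aromatic ring, cyclopropyl in place of sec-butyl gives an at least 55-fold higher number from compound 1 to compound 4 (1.74 log units; beyond the scatter), the first single-place step, and it shows that this position responds sharply to a swap from 4 heavy atoms to 3. A ring in the ether does not by itself remove the read-out, as compound 2 gives 137 nM and compound 3 gives 137 nM.

The compounds shown do not separate the effect of the ring from that of the shorter chain. An open-chain isobutyl ether or a cyclobutylmethyl ether on the same oxygen would bear directly on that question.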